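Aryl substituent swap: fluoro to methyl on compound 2

The source may report more compounds than this note shows. Statements on the series, on what has been measured and on what is new or still open speak of the compounds shown alone.

Of the compounds shown here, two have numbers so far. Compound 1 `CC1(C)OC(C)(C)c2c1nnc(-c1cccc(C(F)(F)F)c1)[n+]2[O-]` carries a trifluoromethyl group on the pendant phenyl ring and in a functional assay on the whole organism with Mus musculus as the target (a higher number here means that more compound is needed for the effect, a lower number that less compound is needed), compound 1 gives 66.7 mg/kg. Compound 2 `CC1(C)OC(C)(C)c2c1nnc(-c1cccc(F)c1)[n+]2[O-]` carries a fluoro group at the same carbon, and in this assay compound 2 gives 74.9 mg/kg. The step between them, a 1.1-fold higher number from compound 1 to compound 2 (0.05 log units; within the scatter), is within the scatter, so the two numbers cannot be told apart; compound 2 stands at one end of the pair only on the face of the digits.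

Compound 3 `Cc1cccc(-c2nnc3c([n+]2[O-])C(C)(C)OC3(C)C)c1` is not yet measured. It differs from compound 2 as follows: methyl in place of fluoro on an aromatic carbon. Going by the values given here, the only measured step that bears on this change is the one from compound 1 to compound 2, a swap of one small substituent for another at this carbon, and it produced no movement beyond the scatter. A further swap of the same kind at the same carbon is therefore expected to leave this assay close to where compound 2 sits, with no step beyond the scatter in either direction; the estimated step is a 1.0-fold lower number from compound 2 to compound 3 (0.02 log units; within the scatter). For compound 3 the estimate in this assay is 72 mg/kg, with a range from 36 mg/kg to 145 mg/kg.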

Compound 3, dose for half-maximal effect: 150 mg/kg
Estimate against measurement, compound 3: 2.1-fold (0.32 log units) below; measured number outside the range, above it.
By their numbers in this assay, from the lowest: compounds 1, 2 and 3 (each within the scatter of the next, the first and the last beyond it).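

In this assay, going by these compounds alone, this carbon is no longer indifferent to its substituent: methyl in place of trifluoromethyl gives the first step beyond the scatter, though a modest one (a 2.2-fold higher number from compound 1 to compound 3 (0.35 log units; beyond the scatter)), whereas the pair of compound 1 and compound 2 gave no step that could be read. Methyl in place of fluoro stays within the scatter (a 2.0-fold higher number from compound 2 to compound 3 (0.30 log units; within the scatter)), so compound 2 and compound 3 cannot be told apart, and the only separation the three 3-substituted phenyl compounds support is the one between compound 1 and compound 3, with compound 2 not distinguishable from either. Nothing at hand explains that separation.

The compounds shown carry only trifluoromethyl, fluoro and methyl at this one carbon, so it remains open whether an amine, a carboxylic acid, a methoxy group or a longer chain such as propyl would extend the spread or reverse it. Also open, on these data alone, is whether the same groups would give the same order on another carbon of the phenyl ring, since all three compounds share a single placement.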